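This account rests on a few compounds, and the source may have more. Where it says the series, first, only, none or still open, it means among the compounds named here.

In a functional assay on Jurkat cells (Homo sapiens) (a lower number here means a stronger inhibitor, a higher number a weaker inhibitor), compound 1 (`CC(C)[C@H](NC(=O)COc1cccc2ccccc12)C(=O)N[C@@H](CC(=O)O)C(=O)COc1ccc(C#N)cc1`) reads > 100000 nM and that reading is a limit of the assay. Within the data shown here, compound 2 (`CC(C)[C@H](NC(=O)COc1cccc2ccccc12)C(=O)N[C@@H](CC(=O)O)C(=O)COc1c(F)c(F)cc(F)c1F`) gives 4500 nM in this assay and so holds the only true number so far. Compound 3 (`CC(C)[C@H](NC(=O)COc1cccc2ccccc12)C(=O)N[C@@H](CC(=O)O)C(=O)COc1c(F)c(F)c(-c2c(F)c(F)c(F)c(F)c2F)c(F)c1F`) has 2,3,4,5,6-pentafluorophenyl in place of hydrogen on an aromatic carbon of the tetrafluorophenyl group of compound 2, and the change counts as 2,3,4,5,6-pentafluorophenyl in place of hydrogen on an aromatic carbon in full. Among the measured compounds shown here, only one measured step bears on this. Placing 2,3,5,6-tetrafluorophenyl where compound 1 has 4-cyanophenyl gave an at least 22-fold lower number from compound 1 to compound 2 (1.34 log units; beyond the scatter) and was large, so this part of the molecule can clearly move the number. That step swapped one group for another and added no ring, so it suggests no direction here. The estimate is therefore a 1.3-fold higher number from compound 2 to compound 3 (0.12 log units; within the scatter) with wide uncertainty either way. For compound 3 the expected value is 6000 nM within an estimated range from 1000 nM to 40000 nM in this assay overall.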

Compound 3, half-maximal inhibitory concentration: 20000 nM
The estimate for compound 3 lay 3.3-fold (0.52 log units) below the measured number; the range from low to high includes it.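

In this assay, placing 2,3,4,5,6-pentafluorophenyl in place of hydrogen on an aromatic carbon of the tetrafluorophenyl group gives a 4.4-fold higher number from compound 2 to compound 3 (0.65 log units; beyond the scatter), so this position is sensitive to substitution, but the cost of this large addition is limited. The earlier step swapped one whole group for another, whereas this one shows that the existing ring can carry a second aromatic ring and still give a true reading, with compound 3 at 20000 nM in this assay. Nothing measured here explains the weaker inhibition.

The compounds shown leave open whether the loss comes with the added ring itself or with its fluorines, a question that a plain phenyl ring on this carbon would address. They also leave open how a much smaller group, such as a methyl group or an amine, would read here.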